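Replacing Methoxy by (2-Methylpyridin-3-yl)oxy in a Modulator Series

This account rests on a few compounds, and the source may have more. Where it says the series, first, only, none or still open, it means among the compounds named here.

Measured compounds:
compound 1, `COc1ccc(-c2ccn(CCC(C)C)c(=O)c2C#N)cc1`: 160%
compound 2, `COc1ccc(-c2ccn(CCC(C)C)c(=O)c2C#N)cc1F`: 160%

Compound 1 and compound 2 share one core and differ only by fluoro in place of hydrogen on an aromatic carbon. In a functional assay on CHO cells for positive allosteric modulation of metabotropic glutamate receptor 2 (Homo sapiens), read by scintillation counting and GTPgammaS binding, with a stated time of 30 min (a lower number here means a smaller maximal response, a higher number a larger maximal response), compound 1 gives 160%, and compound 2 gives 160%. Among the measured compounds shown here, the step of no change at the digits printed from compound 1 to compound 2 (within the scatter) leaves the maximal response where it was, so compound 1 stands level with compound 2 on the numbers so far.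

Compound 3, `Cc1ncccc1Oc1ccc(-c2ccn(CCC(C)C)c(=O)c2C#N)cc1`, arises from compound 1 through a different change: 2-methylpyridin-3-yl in place of methyl on an oxygen on an aromatic ring. Cut one bond further out, this reads as methoxy to (2-methylpyridin-3-yl)oxy.

For the measured compounds named here, the only measured step, no change at the digits printed from compound 1 to compound 2 (within the scatter), does not touch the oxygen. It shows the maximal response holding steady under a small change, but it gives no direct guide to the larger exchange on the oxygen. With nothing pointing either way, the step of no change at the digits printed from compound 1 to compound 3 (within the scatter) is expected to stay within the scatter in this assay, with a wide range to reflect the missing precedent. Compound 3 is estimated to give 160% in this assay, between 120% and 195%.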

Compound 3, largest response reached (Emax), in percent of the reference or control that the assay uses: 256%
Compound 3: middle estimate off by 96 percentage points, on the low side; the measured number lies above the stated range.
By their numbers in this assay, from the lowest: compounds 1 and 2 (each within the scatter of the next); then compound 3.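

In this assay, putting 2-methylpyridin-3-yl in place of methyl on the oxygen on an aromatic ring gives a number 96 percentage points higher from compound 1 to compound 3 (beyond the scatter). Among the compounds shown here, the maximal response therefore proves sensitive to the group on this oxygen, whereas the one earlier step, no change at the digits printed from compound 1 to compound 2 (within the scatter), gave no sign that the series could move at all; a change can lift the response well clear of the level shared by the first two compounds. The data shown offer no measurement that bears on why the larger group has this effect.

With only one exchange at this oxygen, the compounds shown cannot say whether the rise goes with the aromatic ring as a whole, its ring nitrogen or its methyl, and a phenyl, a pyridin-3-yl without the methyl or a simple ethyl on the same oxygen would be needed to separate these. From the compounds shown here alone, it also remains open whether the fluoro of compound 2, which left the response in place on the methoxy compound, would do the same alongside the 2-methylpyridin-3-yl group.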